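From compound 1 to compound 4 on the amide side

The source may report more compounds than this note shows. Statements on the series, on what has been measured and on what is new or still open speak of the compounds shown alone.

Values in an ADME assay on MT4 cells (Homo sapiens) for cytotoxicity, read by MTT assay; a lower number here means that less compound is tolerated, a higher number that more compound is tolerated:
- Compound 1 `Cc1cc(C)cc(S(=O)(=O)c2c(C(=O)NCc3cccc(F)c3F)[nH]c3ccc(Cl)cc23)c1` gives > 51100 nM (a limit)
- Compound 2 `Cc1cc(C)cc(S(=O)(=O)c2c(C(=O)Nc3ccnc(C#N)c3)[nH]c3ccc(Cl)cc23)c1` gives 6840 nM
- Compound 3 `Cc1cc(C)cc(S(=O)(=O)c2c(C(=O)NC(c3ccc(Cl)cc3)C3CC3)[nH]c3ccc(Cl)cc23)c1` gives > 47300 nM (a limit)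

Compound 1 has no exact number and reports > 51100 nM as a limit. Compound 4 `Cc1cc(C)cc(S(=O)(=O)c2c(C(=O)NCC(=O)NC(C)c3ccccc3F)[nH]c3ccc(Cl)cc23)c1` puts (1-(2-fluorophenyl)ethyl)carbamoyl in place of 2,3-difluorophenyl on a saturated chain carbon bound to an amide-type nitrogen. Three measured steps changed the group on that nitrogen. The clear fall, an at least 7.4-fold lower number from compound 1 to compound 2 (0.87 log units; beyond the scatter), is reversed in an at least 6.9-fold higher number from compound 2 to compound 3 (0.83 log units; beyond the scatter), while a step that the two limits leave unreadable from compound 1 to compound 3 gives no size. Compound 4 keeps a six-membered aromatic ring of carbon only, as compound 1 and compound 3 do, and compound 2 at 6840 nM does not. In this assay the expected change is small, at most a slight fall: an at least 1.2-fold lower number from compound 1 to compound 4 (0.10 log units; that floor lies within the scatter) is the estimate. Compound 4 is expected at 40000 nM, within an estimated range of 12000 nM to 65000 nM for this measurement.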

Compound 4, half-maximal cytotoxic concentration: 23000 nM
Beside the measured number, compound 4's estimate is 1.7-fold (0.24 log units) above it, within the range that was stated.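

In this assay, (1-(2-fluorophenyl)ethyl)carbamoyl on a saturated chain carbon bound to an amide-type nitrogen gives an at least 2.2-fold lower number from compound 1 to compound 4 (0.34 log units; beyond the scatter). A fall beyond the scatter is therefore no longer seen with compound 2 alone: compound 4 shows one while keeping a six-membered aromatic ring of carbon only. The true size of the step remains unknown because compound 1 carries only a limit: the limit of > 51100 nM in this assay, at which 1 of the 4 values shown sits.

The compounds shown do not separate the effect of the carbamoyl from that of the fluorophenyl-bearing part attached to it. As far as these compounds go, how an amine or a carboxylic acid at this place would read also remains open.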